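The compounds below may be only part of what the source reports. "The series", "measured", "known", "first", "only" and "open" are said of these compounds alone.

Three compounds built on one shared core have so far been run in an ADME assay on microsomes from liver (Homo sapiens) for metabolic stability, with a stated time of 30 min; on this read-out higher numbers stand for a more stable compound and lower numbers for a less stable compound. Compound 1 `CCCCc1nc(C(C)C)c(CC(=O)OCCC)c(=O)n1Cc1ccc(-c2ccccc2-c2noc(=O)[nH]2)cc1` gives 7.2% in this assay. Compound 2 `CCCCc1nc(C(C)C)c(CC(=O)OCC(C)C)c(=O)n1Cc1ccc(-c2ccccc2-c2noc(=O)[nH]2)cc1` gives 8.8% in this assay, and compound 3 `CCCCc1nc(C)c(CC(=O)OCC(C)C)c(=O)n1Cc1ccc(-c2ccccc2-c2noc(=O)[nH]2)cc1` gives 2.4% in this assay. Compound 2 stands highest of the three numbers, yet the other two sit within the scatter of it: the step of a number 1.6 percentage points higher from compound 1 to compound 2 (within the scatter) and the step of a number 6.4 percentage points lower from compound 2 to compound 3 (within the scatter) are both too small to count as a change on this read-out.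

Compound 4 `CCCCc1nc(C(C)C)c(C(C)C(=O)OCC)c(=O)n1Cc1ccc(-c2ccccc2-c2noc(=O)[nH]2)cc1` has not yet been measured. It differs from compound 2 in one place: 1-(ethoxycarbonyl)ethyl in place of (isobutoxycarbonyl)methyl on an aromatic carbon. The measured step that bears most directly on this change also reworked the ester-bearing chain, and it came out as a number 1.6 percentage points higher from compound 1 to compound 2 (within the scatter). The other step touched the isopropyl group, which stays in place here, and came out as a number 6.4 percentage points lower from compound 2 to compound 3 (within the scatter). Neither of these moved the number beyond the scatter, so for compound 4 in this assay no step beyond the scatter is expected, and the step estimated is a number 0.8 percentage points lower from compound 2 to compound 4 (within the scatter). In this assay compound 4 is therefore expected to give 8%, with a range from 2% to 18%.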

Compound 4, percent of the compound remaining: 11%
The estimate for compound 4 lay 3 percentage points below the measured number; measured number inside the range.
By their numbers in this assay, from the lowest: compounds 3, 1, 2 and 4 (each within the scatter of the next).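

Placing 1-(ethoxycarbonyl)ethyl on the aromatic carbon ortho to the isopropyl group, where (isobutoxycarbonyl)methyl stood, gives a number 2.2 percentage points higher from compound 2 to compound 4 (within the scatter) in this assay when compound 4 is set against compound 2, and the same group in place of (propoxycarbonyl)methyl gives a number 3.8 percentage points higher from compound 1 to compound 4 (within the scatter) on that read-out. The earlier ester-chain step changed only the alkyl end of the ester, whereas this change also puts a branch on the chain at the carbon bound to the aromatic ring, and it still stays within the scatter, so this position has now taken two kinds of change to the ester-bearing chain without a step beyond it. No separate measurement speaks to what lies behind these steps.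

Because the ester end and the branch change together in compound 4, the compounds shown leave open what each contributes alone, as an ethyl ester on the unbranched chain or an isobutyl ester on the branched one would separate them. They also leave open whether a carboxylic acid, an amide or a longer ester chain at this position would move the number in this assay beyond the scatter.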